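Working notes: pyridin-4-yl in place of pyridin-3-yl

The compounds below may be only part of what the source reports. "The series", "measured", "known", "first", "only" and "open" are said of these compounds alone.

Measured compounds
compound 1 `O=C1/C(=C/c2cccnc2)CN(S(=O)(=O)c2ccc(Br)cc2)C/C1=C\c1ccccc1F` — 12800 nM
compound 2 `CC(=O)Nc1ccc(S(=O)(=O)N2C/C(=C\c3cccnc3)C(=O)/C(=C/c3ccccc3F)C2)cc1` — 9640 nM
compound 3 `CC(=O)Nc1ccc(S(=O)(=O)N2C/C(=C\c3ccncc3)C(=O)/C(=C/c3ccccc3F)C2)cc1` — not yet measured

In a functional assay on QGY-7703 cells (Homo sapiens) for cytotoxicity, read by MTT assay, with a stated time of 24 h (on this read-out lower numbers stand for stronger inhibition and higher numbers for weaker inhibition), compound 1 gives 12800 nM and compound 2 gives 9640 nM. Among the compounds with values here, the single measured step is a 1.3-fold lower number from compound 1 to compound 2 (0.12 log units; within the scatter); it is within the scatter, so compound 2 holds the lower of the two numbers without standing apart from compound 1. Compound 3 differs from compound 2 by pyridin-4-yl in place of pyridin-3-yl on a double-bonded chain carbon bound to a double-bonded ring carbon. No measured step touches this part of the structure: the one step shown concerns acetamido in place of bromo on an aromatic carbon, and it was within the scatter. There is therefore no basis for expecting a step beyond the scatter, and the expected step is a 1.0-fold lower number from compound 2 to compound 3 (0.00 log units; within the scatter). Within the data shown here, compound 3 is estimated at 9600 nM in this assay, with a range from 4000 nM to 24000 nM that is kept wide because no measured step bears on the change.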

Compound 3, half-maximal inhibitory concentration: 13700 nM
For compound 3 the middle estimate is 1.4-fold (0.15 log units) below the measured one, within the range that was stated.
By their numbers in this assay, from the lowest: compounds 2, 1 and 3 (each within the scatter of the next).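

Compound 1 and compound 2 both carry pyridin-3-yl on the double-bonded chain carbon bound to a double-bonded ring carbon, so they showed nothing about this position. In this assay, pyridin-4-yl in place of pyridin-3-yl now gives a 1.4-fold higher number from compound 2 to compound 3 (0.15 log units; within the scatter), so this exchange of one pyridine attachment for the other does not separate the pair, which carries acetamido on the aromatic carbon. No supporting data are available that would account for this result.

The compounds shown leave open whether the same holds with bromo in place of acetamido. They also leave open whether a group of a different kind at this position, such as a phenyl ring bearing a carboxylic acid or a dimethylamino group, would produce a step beyond the scatter.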